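Amide swap from cyclohexyl to benzyl

This account rests on a few compounds, and the source may have more. Where it says the series, first, only, none or still open, it means among the compounds named here.

Values in a functional assay on MDA-MB-435 cells (Homo sapiens) for cytotoxicity, read by MTT assay, with a stated time of 72 h; on this read-out higher numbers stand for weaker inhibition and lower numbers for stronger inhibition:
- compound 1 `N[C@H]1CC[C@H](Nc2c(C(=O)NCc3ccc(Cl)cc3Cl)nc(Br)c3cccnc23)CC1`: 5800 nM
- compound 2 `COC(=O)c1nc(Br)c2cccnc2c1N[C@H]1CC[C@H](N)CC1`: > 20000 nM, a limit of the assay
- compound 3 `N[C@H]1CC[C@H](Nc2c(C(=O)NC3CCCCC3)nc(Br)c3cccnc23)CC1`: > 10000 nM, a limit of the assay

Compound 3 has no exact number, only the limit > 10000 nM. Compound 4 `N[C@H]1CC[C@H](Nc2c(C(=O)NCc3ccccc3)nc(Br)c3cccnc23)CC1` keeps the rest of compound 3 and carries benzyl in place of cyclohexyl on an amide-type nitrogen.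

The closest evidence is a change at this same nitrogen, an at least 1.7-fold higher number from compound 1 to compound 3 (0.23 log units; that floor lies within the scatter). That floor lies within the scatter, so it gives only a weak hint. Compound 1 carries 2,4-dichlorobenzyl, a substituted form of the benzyl in compound 4. In this assay compound 1 reaches a measured 5800 nM. A second change removes that whole amide part and lies beyond the scatter: an at least 3.4-fold higher number from compound 1 to compound 2 (0.53 log units; beyond the scatter). Neither change tests plain benzyl directly, so compound 1 offers only a rough guide.

A small move toward a lower number, meaning stronger inhibition, is the expectation, and another limit would be no surprise. The expected size is an at least 1.1-fold lower number from compound 3 to compound 4 (0.04 log units; that floor lies within the scatter). For compound 4 the estimated value is 9000 nM, with an expected range of 3500 nM to 20000 nM.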

Compound 4, half-maximal inhibitory concentration: 7000 nM
The estimate for compound 4 lay 1.3-fold (0.11 log units) above the measured number, within the range that was stated.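

In this assay, the plain benzyl amide gives a second exact number at this nitrogen, and the ring chlorines make no readable difference: a 1.2-fold higher number from compound 1 to compound 4 (0.08 log units; within the scatter). The amide part as a whole now has support from a second compound, with an at least 2.8-fold lower number from compound 2 to compound 4 (0.45 log units; beyond the scatter), so the benzylamino amide and the methoxy compound can be told apart even without the chlorines. For the swap itself, cyclohexyl to benzyl reads as an at least 1.4-fold lower number from compound 3 to compound 4 (0.15 log units; that floor lies within the scatter), which leaves the preference for benzyl over cyclohexyl as a hint and no more.

The step between compound 2 and compound 3 joins two limits of the assay and cannot be read. Still open, going by these compounds, is how far this amide position tolerates other groups, such as a benzyl with a single chlorine, a phenethyl group with its longer chain between the amide nitrogen and the phenyl ring, or a benzyl carrying an amine.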